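The source may hold more compounds than are shown below. What is called first, only, known or untested is meant among the compounds shown, and "the series" means these compounds.

Compound 1 `CCCNc1nc(N)nc2c1ncn2/C=C1/CC1(CO)CO` gives > 300000 nM in an ADME assay on HFF cells (Homo sapiens) for cytotoxicity, with a stated time of 8 days (on this read-out higher numbers stand for lower toxicity in this test and lower numbers for higher toxicity in this test), which is a limit of the assay and not a number.
Compound 2 `CCCSc1nc(N)nc2c1ncn2/C=C1/CC1(CO)CO` gives > 300000 nM in this assay, again a limit of the assay.

Among the compounds with values here, compound 2 therefore stands at the top of what this assay can report, and so does the only other compound measured. Within the data shown here, the one step between measured compounds, a step that the two limits leave unreadable from compound 1 to compound 2, cannot be read, since both of its ends are limits; this is stated in the limit of > 300000 nM in this assay, at which 2 of the 2 values shown sit.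

Compound 3 `CC(C)Sc1nc(N)nc2c1ncn2/C=C1/CC1(CO)CO` differs from compound 2 by isopropyl in place of propyl on a sulfur. The measured step bears only loosely on this change: it swapped the atom that holds the propyl, while here the propyl itself is rearranged into isopropyl on the same sulfur. Nothing in the numbers points to a move in either direction, so no step beyond the usual scatter is expected, and the result is expected most likely to be another limit.

Compound 3 is thus expected to give 300000 nM in this assay, with a range from 100000 nM to 1000000 nM. This amounts to an expected a number no higher from compound 2 to compound 3 (the limit leaves the size open) that stays within the scatter.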

Compound 3, half-maximal cytotoxic concentration: > 300000 nM
Compound 3 gave a limit, no number (the forecaster's own chance of this, stated with the estimate: 85%); the middle value sits exactly at the limit.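

Compound 3 gives > 300000 nM in this assay, again a limit of the assay and not a number. Neither its step from compound 2 nor its step from compound 1 can be read, since both ends of each step are limits: the limit of > 300000 nM in this assay, at which 3 of the 3 values shown sit. The compounds shown leave open whether these changes alter toxicity at all, and by how much.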